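The source may report more compounds than this note shows. Statements on the series, on what has been measured and on what is new or still open speak of the compounds shown alone.

Measured compounds:
Compound 1, `CC[C@H](C)[C@H](NC(=O)c1cccc(Cn2ccnc2)c1)C(=O)NNS(=O)(=O)c1ccccc1`: 18%
Compound 2, `CCCCS(=O)(=O)NNC(=O)[C@@H](NC(=O)c1cccc(Cn2ccnc2)c1)[C@@H](C)CC`: "not determined" (no result reported)

Two compounds have been taken into an assay on HEK293 cells for displacement of a labelled ligand from Type-2 angiotensin II receptor (Homo sapiens), tested at 10 uM; a lower number here means a weaker effect, a higher number a stronger effect of the compound at the concentration tested. Compound 1 gives 18% in this assay. Within the data shown here, compound 2 stands beside it without a result in this assay, so compound 1 holds the only number that has been reported, and there is no step between measured compounds from which a size of effect could be read.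

Compound 3, `CC[C@H](C)[C@H](NC(=O)c1cccc(Cn2ccnc2)c1)C(=O)NNS(=O)(=O)c1c(C)cc(C)cc1C`, keeps the core of compound 1 and changes one group: 2,4,6-trimethylphenyl in place of phenyl on a sulfonyl sulfur. The phenyl leaves and 2,4,6-trimethylphenyl enters on the sulfonyl sulfur; the count of donors and acceptors stays the same.

With nothing to calibrate against, the step is expected to be small, most likely within the usual scatter of the read-out and without a firm direction; the step from compound 1 to compound 3 is estimated at a number 4 percentage points higher from compound 1 to compound 3 (within the scatter). Compound 3 is expected to give about 22% in this assay, somewhere between 5% and 45%.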

Compound 3, a percentage reported as inhibition, at one concentration (the size of the read-out at that concentration, not a potency): 27%
Compound 3: middle estimate off by 5 percentage points, on the low side, within the range that was stated.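

In this assay, among these compounds, the exchange of phenyl for 2,4,6-trimethylphenyl on a sulfonyl sulfur gives the first step that can be read at this position, and it reads a number 9 percentage points higher from compound 1 to compound 3 (within the scatter). The position therefore accepts the larger 2,4,6-trimethylphenyl group, with three more carbon atoms and the same count of donors and acceptors, but this single step shows no firm effect of the change and sets no direction for the series. Nothing available bears on what lies behind this result.

Compound 2 has no reported result, so steps involving it cannot be read, and the sulfonyl sulfur is therefore compared across only these two aromatic groups, both on the same core. Going by these compounds, it remains open whether a 4-methylphenyl group with a single methyl, a naphthyl group, a pyridyl ring or a phenyl ring carrying a carboxylic acid or an amine on the sulfonyl sulfur would give a step beyond the scatter in this assay.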